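Notes on aryl replacement at compound 2

A few compounds are considered here, and "the series" means these few. Any claim that something is new, unique, unknown or untested is made for them only; others in the source may bear on it.

Measured so far, in a functional assay on HT-29 cells (Homo sapiens) for inhibition, read by MTT assay, with a stated time of 72 h; a lower number here means a stronger inhibitor, a higher number a weaker inhibitor:
- compound 1, `COc1cc2c(Oc3ccc(NC(=O)c4nn(-c5ccccc5OC(F)(F)F)c(=O)cc4C)cc3F)ccnc2cc1OCCCN1CCCC1`, gives 180 nM
- compound 2, `COc1cc2c(Oc3ccc(NC(=O)c4nn(-c5ccccc5OC(F)(F)F)c(=O)cc4C)cc3F)ccnc2cc1OCCCN1CCC(C)CC1`, gives 250 nM
- compound 3, `COc1cc2c(Oc3ccc(NC(=O)c4nn(-c5ccccc5OC(F)(F)F)c(=O)cc4C)cc3F)ccnc2cc1OCCCN1CCN(C)CC1`, gives 180 nM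

Compound 2 has the highest of the three numbers, but its steps to the others are small: a 1.4-fold higher number from compound 1 to compound 2 (0.14 log units; within the scatter) and a 1.4-fold lower number from compound 2 to compound 3 (0.14 log units; within the scatter), both within the scatter, as is no change at the digits printed from compound 1 to compound 3 (within the scatter). The three compounds are therefore indistinguishable in this assay.

Compound 4, `COc1cc2c(Oc3ccc(NC(=O)c4nn(-c5ccc(Cl)cc5)c(=O)cc4C)cc3F)ccnc2cc1OCCCN1CCC(C)CC1`, differs from compound 2 by 4-chlorophenyl in place of 2-(trifluoromethoxy)phenyl on an aromatic nitrogen. Among the compounds with values here, none of the measured steps touches this position; all three concern only the amine at the end of the chain. Within the data shown here, there is thus no measured step that bears on the change from compound 2 to compound 4, and no direction can be argued from the data.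

In the absence of such evidence the number for compound 4 is expected to stay near that of compound 2, with a wide range, so that the step of no change at the digits printed from compound 2 to compound 4 (within the scatter) is estimated to lie within the scatter. The estimate for compound 4 in this assay is 250 nM, within 70 nM to 900 nM.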

Compound 4, half-maximal inhibitory concentration: 180 nM
Estimate against measurement, compound 4: 1.4-fold (0.14 log units) above, and the stated range covers the measured number.
By their numbers in this assay, from the lowest: compounds 1, 3, 4 and 2 (each within the scatter of the next).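

In this assay, the change on the aromatic nitrogen gives a step within the scatter (a 1.4-fold lower number from compound 2 to compound 4 (0.14 log units; within the scatter)), so this position accepts 4-chlorophenyl in place of 2-(trifluoromethoxy)phenyl with no readable change while the amine end stays 4-methylpiperidin-1-yl. Within the data shown here, the earlier compounds varied only that amine, so this is the first sign that the aryl group can also be exchanged, at least for this pair. No measured property bears on why the number holds.

The change swaps both the substituent and its place on the phenyl ring, and the two cannot be separated from this pair. Open, from the compounds shown here alone, are how unsubstituted phenyl or a saturated cyclohexyl group would read here, and whether 4-chlorophenyl behaves the same with a pyrrolidin-1-yl or 4-methylpiperazin-1-yl end.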